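The source may report more compounds than this note shows. Statements on the series, on what has been measured and on what is new or still open speak of the compounds shown alone.

Compound 1 `CC(C)=CCC1=C(OCc2cn(-c3ccnc4cc(Cl)ccc34)nn2)C(=O)c2ccccc2C1=O` gives 1940000 nM in an ADME assay on HepG2 cells (Homo sapiens) for cytotoxicity, read by MTT assay, with a stated time of 24 h; on this read-out lower numbers stand for higher toxicity in this test and higher numbers for lower toxicity in this test.
Compound 2 `CC(C)=CCC1=C(OCc2cn(C3CCNCC3)nn2)C(=O)c2ccccc2C1=O` gives 570000 nM in this assay.
Compound 3 `CC(C)=CCC1=C(OCc2cn(-c3ccc([N+](=O)[O-])cc3)nn2)C(=O)c2ccccc2C1=O` gives 540000 nM in this assay.

Compound 3 has the lowest of the three numbers, but compound 2 sits within the scatter of it (a 1.1-fold lower number from compound 2 to compound 3 (0.02 log units; within the scatter)), and only compound 1 stands clearly apart (a 3.6-fold lower number from compound 1 to compound 3 (0.56 log units; beyond the scatter)). Compound 4 `COc1ccc(-n2cc(COC3=C(CC=C(C)C)C(=O)c4ccccc4C3=O)nn2)c([N+](=O)[O-])c1` differs from compound 3 in one place: 4-methoxy-2-nitrophenyl in place of 4-nitrophenyl on an aromatic nitrogen. The two measured steps that exchange the group on this aromatic nitrogen are the ones just given: one modest, one within the scatter. The change to compound 4 adds a methoxy group and shifts the nitro group on the same ring, a smaller alteration than either measured swap, so no step beyond the scatter is expected: a 1.1-fold lower number from compound 3 to compound 4 (0.03 log units; within the scatter). Compound 4 is therefore estimated at 500000 nM, between 230000 nM and 1100000 nM.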

Compound 4, half-maximal cytotoxic concentration: 532000 nM
Beside the measured number, compound 4's estimate is 1.1-fold (0.03 log units) below it; the range from low to high includes it.
By their numbers in this assay, from the lowest: compounds 4, 3 and 2 (each within the scatter of the next); then compound 1.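

With 4-methoxy-2-nitrophenyl in place of 4-nitrophenyl, the two numbers in this assay cannot be told apart (a 1.0-fold lower number from compound 3 to compound 4 (0.01 log units; within the scatter)), and the same holds with piperidin-4-yl as the group replaced (a 1.1-fold lower number from compound 2 to compound 4 (0.03 log units; within the scatter)). Only the 7-chloroquinolin-4-yl group stands apart (a 3.6-fold lower number from compound 1 to compound 4 (0.56 log units; beyond the scatter)), so three of the four groups on this aromatic nitrogen now share one level. Still open, on these data alone, is whether a carboxylic acid or a longer alkyl chain at this position would join that level or match compound 1. No measurement shown here explains these results.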